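The source may report more compounds than this note shows. Statements on the series, on what has been measured and on what is new or still open speak of the compounds shown alone.

Of the compounds shown here, three have so far been tested in a functional assay on HT-29 cells (Homo sapiens) for cytotoxicity, read by sulforhodamine B assay, with a stated time of 48 h; on this read-out higher numbers stand for weaker inhibition and lower numbers for stronger inhibition. Compound 1 `CCc1ccccc1OS(=O)(=O)c1cccc(NC(=O)NCCCCl)c1` gives 23000 nM in this assay. Compound 3 `CCNC(=O)Nc1cccc(S(=O)(=O)Oc2ccccc2CC)c1` gives 33000 nM in this assay. Compound 3 differs from compound 1 only by hydrogen in place of chloromethyl on a saturated chain carbon, two bonds along the chain from an amide-type nitrogen. That step measured a 1.4-fold higher number from compound 1 to compound 3 (0.16 log units; within the scatter). Compound 2 `Cc1ccccc1OS(=O)(=O)c1ccc(NC(=O)NCCCCl)cc1` gives 26000 nM in this assay; the difference between the core of compound 2 and the core of compound 1 is not broken down here. Compound 4 `CCNC(=O)Nc1ccc(S(=O)(=O)Oc2ccccc2C)cc1` has not yet been measured. For the measured compounds named here, it differs from compound 2 by hydrogen in place of chloromethyl on a saturated chain carbon, two bonds along the chain from an amide-type nitrogen, which is the same change, at the same place, as the one that turned compound 1 into compound 3. The expected step for compound 4 is therefore a 1.3-fold higher number from compound 2 to compound 4 (0.12 log units; within the scatter). This expectation rests on the measured step of a 1.4-fold higher number from compound 1 to compound 3 (0.16 log units; within the scatter). Compound 4 is estimated to give 34000 nM in this assay, probably between 17000 nM and 68000 nM.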

Compound 4, half-maximal inhibitory concentration: 12000 nM
For compound 4 the middle estimate is 2.8-fold (0.45 log units) above the measured one; the whole stated range lies above it.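

In this assay, going from 3-chloropropyl to ethyl gave a 2.2-fold lower number from compound 2 to compound 4 (0.34 log units; beyond the scatter) while the same change on the core of compound 1 gave no shift beyond the scatter. A step measured on one core therefore did not carry over to the other, and the two cores responded differently: the same change on two cores in this assay, a 1.4-fold higher number (0.16 log units; within the scatter) from compound 1 to compound 3 and a 2.2-fold lower number (0.34 log units; beyond the scatter) from compound 2 to compound 4, 3.1-fold (0.49 log units) apart, beyond the scatter of two such steps. This does not show why they differ, and one pair per core cannot predict how the change would behave on any further core.

The compounds shown leave open whether the chlorine or the chain length matters more. A plain propyl chain would separate these two, and a 3-aminopropyl chain would test another group on both cores.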